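The compounds below may be only part of what the source reports. "The series", "measured", "known", "first", "only" and "open" are said of these compounds alone.

Going by the values given here, in a functional assay on Shh Light II cells (Mus musculus) for inhibition, read by a luciferase reporter (a higher number here means a weaker inhibitor, a lower number a stronger inhibitor), compound 2 `O=C(NC1CCCCC1)N1CCN(c2nc(-c3ccc4ccccc4n3)no2)CC1` gives 53 nM, the lowest of the three numbers so far. In the same read-out, compound 1 `O=C(Nc1ccccc1Cl)N1CCN(c2nc(-c3ccc4ccccc4n3)no2)CC1` gives 140 nM and compound 3 `COc1ccccc1N(C)C(=O)N1CCC(c2nc(-c3ccc4ccccc4n3)no2)CC1` gives 3100 nM, the highest number of the set. The next structure, compound 4 `Cn1c(-c2noc(N3CCN(C(=O)NC4CCCCC4)CC3)n2)nc2ccccc21`, keeps the cyclohexyl group of compound 2 but carries 1-methyl-1H-benzimidazol-2-yl in place of quinolin-2-yl on an aromatic carbon. Among the compounds with values here, the only measured single-place step is a 2.6-fold lower number from compound 1 to compound 2 (0.42 log units; beyond the scatter). It is modest and concerns cyclohexyl in place of 2-chlorophenyl on an amide-type nitrogen, so it lies elsewhere in the molecule. All three measured compounds carry quinolin-2-yl, and the data therefore contain no direct test of this swap. With compound 2 at 53 nM at the low end of the series, a higher number is the more likely direction, though its size is poorly constrained. The expected change is a 3.8-fold higher number from compound 2 to compound 4 (0.58 log units; beyond the scatter), a moderate step. The estimated value for compound 4 is 200 nM, with an expected range from 40 nM to 1500 nM.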

Compound 4, half-maximal inhibitory concentration in the Shh Light II assay: 5 nM
The estimate for compound 4 lay 40-fold (1.60 log units) above the measured number; measured number outside the range, below it.
By their numbers in the Shh Light II assay, from the lowest: compound 4; then compound 2; then compound 1; then compound 3.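

Going by these compounds alone, in the Shh Light II assay, compound 2 gives 53 nM and compound 4 gives 5 nM: the swap of quinolin-2-yl for 1-methyl-1H-benzimidazol-2-yl gives an 11-fold lower number from compound 2 to compound 4 (1.03 log units; beyond the scatter), the first direct reading at this aromatic carbon, and this step is larger than the one on the amide-type nitrogen, a 2.6-fold lower number from compound 1 to compound 2 (0.42 log units; beyond the scatter). In a physicochemical assay for lipophilicity (a higher number here means a more lipophilic compound, a lower number a more polar compound), compound 2 gives 2.76 and compound 4 gives 2.57, and the same swap reads a number 0.19 log units lower from compound 2 to compound 4 (within the scatter), so the two compounds do not separate in that read-out while they separate clearly in the cell assay. Nothing given here accounts for the size of the step.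

Open, as far as these compounds go, is how 1H-benzimidazol-2-yl without the methyl group, or a 1-ethyl-1H-benzimidazol-2-yl, would read at this position, which would separate the contribution of the methyl group from that of the ring system. Also open, from the compounds shown here alone, is whether the swap would give a step of similar size with 2-chlorophenyl in place of cyclohexyl.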